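A few compounds are considered here, and "the series" means these few. Any claim that something is new, unique, unknown or untested is made for them only; others in the source may bear on it.

Measured so far:
compound 1 `CC(=O)OCc1ccc2oc(=O)c(C(=O)Oc3cccc(Br)c3)cc2c1`: 21.8%
compound 2 `CC(=O)OCc1ccc2oc(=O)c(C(=O)Sc3cccc(Br)c3)cc2c1`: 70.9%
compound 3 `CC(=O)OCc1ccc2oc(=O)c(C(=O)Nc3cccc(Cl)c3)cc2c1`: 66.9%

In a functional assay on HT-1080 cells (Homo sapiens), read by transwell migration, with a stated time of 24 h, tested at 1 uM (a higher number here means a weaker effect of the compound at the concentration tested, a lower number a stronger effect), compound 3 stands second highest of the three numbers: nearest is compound 2, a number 4 percentage points lower from compound 2 to compound 3 (within the scatter), furthest is compound 1, a number 45.1 percentage points higher from compound 1 to compound 3 (beyond the scatter). Compound 4 `CC(=O)OCc1ccc2oc(=O)c(C(=O)N(C)c3ccccc3Cl)cc2c1` differs from compound 3 in one place: (2-chlorophenyl)(methyl)amino in place of (3-chlorophenyl)amino on a carbonyl carbon. For the measured compounds named here, no measured step alters this part of the molecule; the measured steps change only the atom linking the carbonyl to the ring, a number 49.1 percentage points higher from compound 1 to compound 2 (beyond the scatter) and a number 45.1 percentage points higher from compound 1 to compound 3 (beyond the scatter), both large, which shows that this position can move the read-out strongly. Going by the values given here, with no direct precedent, compound 4 is expected near compound 3, at 65%, within a wide range from 35% to 95%. The expected step is a number 1.9 percentage points lower from compound 3 to compound 4 (within the scatter).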

Compound 4, a percentage reported as activity, at one concentration (the size of the read-out at that concentration, not a potency): 62.8%
Estimate against measurement, compound 4: 2.2 percentage points above, within the range that was stated.
By their numbers in this assay, from the lowest: compound 1; then compounds 4, 3 and 2 (each within the scatter of the next).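

In this assay, moving to (2-chlorophenyl)(methyl)amino gives up the hydrogen-bond donor of (3-chlorophenyl)amino, yet the read-out holds level, a number 4.1 percentage points lower from compound 3 to compound 4 (within the scatter). The new compound also stays level with the (3-bromophenyl)sulfanyl compound, a number 8.1 percentage points lower from compound 2 to compound 4 (within the scatter), while remaining well apart from the 3-bromophenoxy compound, a number 41 percentage points higher from compound 1 to compound 4 (beyond the scatter). Nothing shown gives a reason for these numbers.

The chlorine position and the methyl changed together. A (2-chlorophenyl)amino group would be needed to separate them. A (3-bromophenyl)amino group would likewise separate the linking atom from the halogen.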